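Swapping the Sulfonyl Ring in a Prostaglandin Antagonist Series

A few compounds are considered here, and "the series" means these few. Any claim that something is new, unique, unknown or untested is made for them only; others in the source may bear on it.

Compound 1 `COc1ccc(Cl)cc1S(=O)(=O)NC(=O)NC/C=C1\CCCc2cnn(Cc3ccc(Cl)cc3Cl)c21`: 8 nM
Compound 2 `O=C(NC/C=C1\CCCc2cnn(C3CCN(c4ccc(F)cc4)CC3)c21)NS(=O)(=O)c1cc(Cl)c(Cl)s1`: 6 nM
Compound 3 `O=C(NC/C=C1\CCCc2cnn(-c3ccc(C(F)(F)F)cc3)c21)NS(=O)(=O)c1cc(Cl)c(Cl)s1`: 4 nM

Three compounds sharing one core were tested in a functional assay on CHO-K1 cells for antagonist activity at prostaglandin E2 receptor EP3 subtype (Homo sapiens), read by TR-FRET and cAMP accumulation, with a stated time of 30 min; on this read-out lower numbers stand for stronger inhibition and higher numbers for weaker inhibition. Compound 1 shows the highest of the three numbers, yet its gaps to compound 2 and to compound 3 both lie within the usual scatter, so the three cannot be ranked against each other.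

Compound 4 `Cc1ncc(S(=O)(=O)NC(=O)NC/C=C2\CCCc3cnn(Cc4ccc(Cl)cc4Cl)c32)s1` has not yet been measured. It differs from compound 1 in one place: 2-methyl-1,3-thiazol-5-yl in place of 5-chloro-2-methoxyphenyl on a sulfonyl sulfur. No measured pair isolates this exchange, so the expectation rests only on the three numbers shown, which stay close across quite different groups on the sulfonyl sulfur. The step from compound 1 to compound 4 is therefore expected to be small, a 1.5-fold higher number from compound 1 to compound 4 (0.18 log units; within the scatter), in either direction or none beyond the scatter. Compound 4 is estimated at 12 nM, with a range from 4 nM to 40 nM.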

Compound 4, half-maximal inhibitory concentration: 9 nM
For compound 4 the middle estimate is 1.3-fold (0.12 log units) above the measured one, within the range that was stated.
By their numbers in this assay, from the lowest: compounds 3, 2, 1 and 4 (each within the scatter of the next, the first and the last beyond it).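

Compounds 1 and 4 are the only pair shown that isolates the group on the sulfonyl sulfur, and the step is a 1.1-fold higher number from compound 1 to compound 4 (0.05 log units; within the scatter) within the usual scatter. With the rest of compound 1 unchanged, a five-membered 2-methyl-1,3-thiazol-5-yl ring with fewer heavy atoms can therefore replace the six-membered 5-chloro-2-methoxyphenyl ring with no readable change in this read-out. No measurement here explains this result.

Going by these compounds, whether the same holds for a non-aromatic group on the sulfur, such as cyclopropyl or a butyl chain, remains open.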